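A few compounds are considered here, and "the series" means these few. Any claim that something is new, unique, unknown or untested is made for them only; others in the source may bear on it.

Compound 1 `Cc1cccc(/C(N)=N/NC(=S)N2CCSCC2)n1` is tested in a functional assay on A-375 cells (Homo sapiens) for cytotoxicity, read by MTT assay, with a stated time of 72 h, tested at 3 uM (a higher number here means more inhibition of growth at the concentration tested, a lower number less inhibition of growth), where compound 1 gives 60.1%. Compound 2 `Cc1cccc(/C(N)=N/NC(=S)N2CCOCC2)n1` differs from compound 1 in one place, (morpholin-4-yl in place of thiomorpholin-4-yl on a thiocarbonyl carbon), and in this assay compound 2 gives 34.7%. That single exchange produced a number 25.4 percentage points lower from compound 1 to compound 2 (beyond the scatter). Compound 3 `N/C(=N\NC(=S)N1CCSCC1)c1ccc(F)cn1` carries a different core from compound 1; the difference between the two cores is not broken down here. In this assay compound 3 gives 62.2%, a number that lies within the scatter of compound 1 and beyond the scatter of compound 2. Compound 4 `N/C(=N\NC(=S)N1CCOCC1)c1ccc(F)cn1` has not yet been measured; it stands to compound 3 as compound 2 stands to compound 1, through (morpholin-4-yl in place of thiomorpholin-4-yl on a thiocarbonyl carbon). Since the surroundings of the place are described in the same words in both cases, this is the same change made a second time. Among the measured compounds shown here, the expected step for compound 4 is a number 25.2 percentage points lower from compound 3 to compound 4 (beyond the scatter), set beside the earlier step because the one measured instance of this change gave a number 25.4 percentage points lower from compound 1 to compound 2 (beyond the scatter). Compound 4 is therefore estimated at 37% in this assay, with a likely span from 20% to 55%.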

Compound 4, percent growth inhibition at one concentration: 66.4%
Beside the measured number, compound 4's estimate is 29.4 percentage points below it, outside the stated range (above it).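

In this assay, putting morpholin-4-yl in place of thiomorpholin-4-yl on the thiocarbonyl carbon of the core of compound 3 gave a number 4.2 percentage points higher from compound 3 to compound 4 (within the scatter), so the loss seen on the core of compound 1 did not recur. The size of this exchange therefore did not carry from one core to the other in these four compounds: the same change on two cores in this assay, a number 25.4 percentage points lower (beyond the scatter) from compound 1 to compound 2 and a number 4.2 percentage points higher (within the scatter) from compound 3 to compound 4, 29.6 percentage points apart, beyond the scatter of two such steps This shows that the outcome of the exchange depends on the core in these two pairs, but it does not show which feature of the cores is responsible, and two pairs give no rule for predicting the step on a further core.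

The compounds shown leave open how the same exchange behaves on cores other than these two, and which of the two steps would be the more usual one. They also leave open whether another group on the thiocarbonyl carbon, such as piperidin-1-yl or an open-chain dimethylamino group, would track thiomorpholin-4-yl or morpholin-4-yl on each core.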